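The source may report more compounds than this note shows. Statements on the series, on what has been measured and on what is new or still open speak of the compounds shown alone.

Of the compounds shown here, three sharing one core have been measured in a functional assay on the whole organism (arterial blood) with Rattus norvegicus as the target; on this read-out higher numbers stand for an effect only at larger amounts of compound and lower numbers for an effect already at smaller amounts. Compound 1 (`Cc1nc2cnccc2n1CC1CCN(C(=O)CC(C)c2ccc(N)cc2)CC1`) gives 0.24 mg/kg, compound 2 (`Cc1nc2cnccc2n1CC1CCN(C(=O)CC(C)(C)c2ccc(N)cc2)CC1`) gives 0.099 mg/kg, and compound 3 (`C/C(=C\C(=O)N1CCC(Cn2c(C)nc3cnccc32)CC1)c1ccc(N)cc1`) gives 0.17 mg/kg. The value of compound 3 lies within the usual scatter of both of the others, so it cannot be ranked against either.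

The unmeasured compound 4 (`Cc1nc2cnccc2n1CC1CCN(C(=O)/C=C(\c2ccccc2)c2ccc(N)cc2)CC1`) carries phenyl in place of methyl on a double-bonded chain carbon bound to an aromatic carbon and a double-bonded chain carbon.

Within the data shown here, only one measured step offers any guide, and it does so loosely. This is a 2.4-fold lower number from compound 1 to compound 2 (0.38 log units; beyond the scatter), with methyl in place of hydrogen on a saturated chain carbon bound to an aromatic carbon and two saturated chain carbons. That step is modest, and it concerns a different exchange on a different kind of carbon. Among the measured compounds shown here, no measured pair shows phenyl entering at a carbon of this kind, so the data give no firm direction. The expectation is therefore no step beyond the scatter, with wide uncertainty on either side. The expected change is a 1.2-fold higher number from compound 3 to compound 4 (0.07 log units; within the scatter). The estimated value for compound 4 is 0.2 mg/kg, with an expected range of 0.07 mg/kg to 0.6 mg/kg.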

Compound 4, dose for 50% inhibition: 0.01 mg/kg
Estimate against measurement, compound 4: 20-fold (1.30 log units) above; the measured number lies below the stated range.
By their numbers in this assay, from the lowest: compound 4; then compounds 2, 3 and 1 (each within the scatter of the next, the first and the last beyond it).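

In this assay, among these compounds, phenyl in place of methyl on a double-bonded chain carbon bound to an aromatic carbon and a double-bonded chain carbon gives a 17-fold lower number from compound 3 to compound 4 (1.23 log units; beyond the scatter), while the only earlier step, methyl in place of hydrogen on a saturated chain carbon, gave a 2.4-fold lower number from compound 1 to compound 2 (0.38 log units; beyond the scatter). The earlier compounds shown here carried only methyl groups or hydrogen at this part of the chain, so they did not show that a group of six heavy atoms with a six-membered aromatic ring is accepted here, nor that it brings the effect down to much smaller amounts of compound. Nothing among the data shown explains this large step.

Going by these compounds, it remains open whether the step depends on an aromatic ring or would also appear with cyclohexyl, or with a shorter group such as ethyl, on the same carbon. On these data alone, it is equally open whether phenyl would give a step of this kind on the saturated chain of compound 1, and how a methoxy group or a carboxylic acid on the new phenyl would change the number.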